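Swapping the Anilino Group for a 2-Hydroxyphenyl Group

The source may hold more compounds than are shown below. What is called first, only, known or untested is meant among the compounds shown, and "the series" means these compounds.

Of the compounds shown here, three built on a shared core have been measured in a functional assay, read by spectrophotometry, with a stated time of 3 min; a lower number here means a stronger inhibitor, a higher number a weaker inhibitor. Compound 1 `O=c1cc(/C=N\Nc2ccccc2)c2ccc(OCc3ccccc3)cc2o1` gives 13200 nM, which places it second highest of the three numbers. Compound 2 `O=c1cc(/C=N\c2ccc(O)cc2)c2c(OCc3ccccc3)cc(OCc3ccccc3)cc2o1` gives 3570 nM, and compound 3 `O=c1cc(/C=N\Nc2ccccc2)c2c(OCc3ccccc3)cc(OCc3ccccc3)cc2o1` gives 40100 nM. Adding a benzyloxy group gave a 3.0-fold higher number from compound 1 to compound 3 (0.48 log units; beyond the scatter). Replacing the 4-hydroxyphenyl group of compound 2 with an anilino group gave an 11-fold higher number from compound 2 to compound 3 (1.05 log units; beyond the scatter).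

Compound 4 `O=c1cc(/C=N\c2ccccc2O)c2ccc(OCc3ccccc3)cc2o1` differs from compound 1 in one place: 2-hydroxyphenyl in place of anilino on a double-bonded nitrogen. Going by the values given here, the only measured step that bears on this is the one from compound 2 to compound 3, read in the opposite direction, on a core carrying two benzyloxy groups rather than one, and with a 4-hydroxyphenyl rather than a 2-hydroxyphenyl group. A lower number in this assay, meaning a stronger inhibitor, is therefore expected, though its size is uncertain. Compound 4 is expected to give about 2000 nM, within a range from 600 nM to 7000 nM. The expected step is a 6.6-fold lower number from compound 1 to compound 4 (0.82 log units; beyond the scatter).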

Compound 4, half-maximal inhibitory concentration: 1290 nM
The estimate for compound 4 lay 1.6-fold (0.19 log units) above the measured number; measured number inside the range.
By their numbers in this assay, from the lowest: compound 4; then compound 2; then compound 1; then compound 3.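

In this assay, putting 2-hydroxyphenyl in place of anilino on the core with one benzyloxy group gave a 10-fold lower number from compound 1 to compound 4 (1.01 log units; beyond the scatter) and a stronger inhibitor, a large step for a swap between groups that match in heavy atoms, donors and acceptors as counted. Together with an 11-fold higher number from compound 2 to compound 3 (1.05 log units; beyond the scatter) on the core with two benzyloxy groups, it shows that in both pairs the anilino compound has the higher number, with no pair here going against this. No measurement at hand explains why the hydroxyphenyl groups give the lower numbers.

Still open, going by these compounds, is how 2-hydroxyphenyl and 4-hydroxyphenyl compare on one and the same core, as the compounds carrying them also differ in their benzyloxy groups. Also open, on these data alone, is whether an amine or a carboxylic acid in place of the hydroxyl would keep the lower number.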